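A few compounds are considered here, and "the series" means these few. Any claim that something is new, unique, unknown or untested is made for them only; others in the source may bear on it.

Compound 3 `COc1ccc(-c2cc3ccccc3nc2/C=C/C(=O)c2ccsc2)cc1` carries a thiophen-3-yl group on the carbonyl carbon; in a functional assay on SK-BR-3 cells (Homo sapiens) for antiproliferative activity, read by XTT assay, with a stated time of 72 h (a lower number here means a stronger inhibitor, a higher number a weaker inhibitor), compound 3 gives 660 nM, the lowest of the three numbers, though compound 1 `COc1ccc(-c2cc3ccccc3nc2/C=C/C(=O)c2ccccc2)cc1` with 700 nM lies within the scatter of it and only compound 2 `COc1ccc(-c2cc3ccccc3nc2/C=C/C(=O)c2ccc(OC)cc2OC)cc1` with 2260 nM stands clearly apart. Compound 4 `COc1ccc(-c2cc3ccccc3nc2/C=C/C(=O)c2sccc2N)cc1` differs from compound 3 in one place: 3-aminothiophen-2-yl in place of thiophen-3-yl on a carbonyl carbon. The measured steps at this position are a 1.1-fold lower number from compound 1 to compound 3 (0.03 log units; within the scatter) and a 3.2-fold higher number from compound 1 to compound 2 (0.51 log units; beyond the scatter); the step of a 3.4-fold lower number from compound 2 to compound 3 (0.53 log units; beyond the scatter) is the same comparison seen from compound 2. Going by the values given here, no measured step introduces an amino group or moves the point of attachment of the ring on the carbonyl carbon, so the direction for compound 4 is not settled by the data, while every variation seen at this position has stayed within a modest span. The expected step is therefore a 1.4-fold higher number from compound 3 to compound 4 (0.13 log units; within the scatter), with a range open in both directions. In this assay compound 4 is expected to give 900 nM, between 300 nM and 2800 nM.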

Compound 4, half-maximal inhibitory concentration: > 10000 nM
Compound 4: no number, only a limit; the forecaster's own chance of this, stated with the estimate: 5%; middle value at least 11-fold (1.04 log units) away from the limit.
By their numbers in this assay, from the lowest: compounds 3 and 1 (each within the scatter of the next); then compound 2. At a limit, above all of these: compound 4.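

Compound 4 gives no number in this assay, only a limit: the limit of > 10000 nM in this assay, at which 1 of the 4 values shown sits. Going by these compounds alone, the position is less tolerant than the earlier compounds suggested, since 3-aminothiophen-2-yl on the carbonyl carbon gives an at least 15-fold higher number from compound 3 to compound 4 (1.18 log units; beyond the scatter) and, against the phenyl group, an at least 14-fold higher number from compound 1 to compound 4 (1.15 log units; beyond the scatter). Even 2,4-dimethoxyphenyl, the one earlier group that stood clearly apart, leaves an at least 4.4-fold higher number from compound 2 to compound 4 (0.64 log units; beyond the scatter), so this change reaches beyond the modest span seen so far at this position.

The step combines two changes, the amino group and the ring's point of attachment on the carbonyl carbon, and the compounds shown do not separate them. As far as these compounds go, whether plain thiophen-2-yl, or a hydroxyl or acetamido group in place of the amino group, would return to the range of compound 3 stays open.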